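Ethyl to benzyl against a cytotoxicity limit

The source may hold more compounds than are shown below. What is called first, only, known or untested is meant among the compounds shown, and "the series" means these compounds.

For compound 1 (`CN1C(=O)C(C2=NS(=O)(=O)c3cc(NS(C)(=O)=O)ccc3N2)=C(O)C2CCCC21`) the entry in an ADME assay on Huh-7 cells (Homo sapiens) for cytotoxicity, with a stated time of 72 h (on this read-out higher numbers stand for lower toxicity in this test and lower numbers for higher toxicity in this test), reads "not determined" (no result reported) and offers no comparison. Compound 2 (`CCN1C(=O)C(C2=NS(=O)(=O)c3cc(NS(C)(=O)=O)ccc3N2)=C(O)C2CCCC21`) gives > 33000 nM in this assay and this is a limit of the assay, not a number. Among the compounds with values here, the series therefore offers no exact value and no measured step as a guide. Compound 3 (`CS(=O)(=O)Nc1ccc2c(c1)S(=O)(=O)N=C(C1=C(O)C3CCCC3N(Cc3ccccc3)C1=O)N2`) keeps the shared core and differs from compound 2 by one change (phenyl in place of methyl on a saturated chain carbon bound to an amide-type nitrogen in a ring): phenyl in place of methyl on a saturated chain carbon bound to an amide-type nitrogen in a ring, which turns ethyl into benzyl. The expected step of an at least 1.1-fold lower number from compound 2 to compound 3 (0.04 log units; that floor lies within the scatter) is small, either within the scatter or a modest move towards lower numbers. Compound 3 is estimated at 30000 nM with an expected range from 12000 nM to 60000 nM and another report as a limit is likely.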

Compound 3, half-maximal cytotoxic concentration: > 33000 nM
Compound 3 gave a limit, no number; the forecaster's own chance of this, stated with the estimate: 65%; middle value at least 1.1-fold (0.04 log units) away from the limit.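

Within the data shown here, no step from ethyl to benzyl can be read between compound 2 and compound 3, because both results are limits and not numbers: the limit of > 33000 nM in this assay, at which 2 of the 3 values shown sit. Still open, on these data alone, are the exact values of the two compounds and whether ethyl and benzyl differ on this read-out at all.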